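The source may hold more compounds than are shown below. What is called first, only, known or untested is meant among the compounds shown, and "the series" means these compounds.

Compound 1 (`COc1cccnc1-c1nc2ccc(-c3nc4c(C)ncc(C)n4n3)cc2[nH]1`) serves as the reference point for this step. In an ADME assay on microsomes from liver (Rattus norvegicus) for metabolic stability, read by LC-MS, in the presence of a further agent that is not named here (on this read-out lower numbers stand for slow clearance and higher numbers for fast clearance), compound 1 gives 5.4 mL.min-1.g-1 as the lower of the two numbers in hand. In this assay compound 2 (`Cc1ncc(C)n2nc(-c3ccn4cc(-c5ccc(Br)cc5)nc4n3)nc12`) gives 15 mL.min-1.g-1 and so stands higher, beyond the usual scatter. These two compounds differ in more than one place, so that gap isolates no single change.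

Compound 3 (`Cc1ncc(C)n2nc(-c3ccc4nc(-c5ccccc5)[nH]c4c3)nc12`) has not yet been measured. Its change from compound 1 (phenyl in place of 3-methoxypyridin-2-yl on an aromatic carbon) is phenyl in place of 3-methoxypyridin-2-yl on an aromatic carbon. Going by the values given here, no measured pair isolates this change, so the expectation rests on little. Compound 2 also has no methoxy group and gives 15 mL.min-1.g-1 as its value, which tilts the expectation upward.

A modest rise is expected in this assay with a 1.9-fold higher number from compound 1 to compound 3 (0.27 log units; within the scatter) as the estimated step, close to the usual scatter in size. The estimate for compound 3 is 10 mL.min-1.g-1 with 4.5 mL.min-1.g-1 to 22 mL.min-1.g-1 as the expected range.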

Compound 3, intrinsic clearance in microsomes: 27.4 mL.min-1.g-1
Estimate against measurement, compound 3: 2.7-fold (0.44 log units) below, outside the stated range (above it).
By their numbers in this assay, from the lowest: compound 1; then compounds 2 and 3 (each within the scatter of the next).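

Going by these compounds alone, on the aromatic carbon between two ring nitrogen atoms, phenyl in place of 3-methoxypyridin-2-yl gives in this assay a 5.1-fold higher number from compound 1 to compound 3 (0.71 log units; beyond the scatter), the first change that can be read in one place, and the step lies beyond the scatter. Clearance in this read-out therefore responds to the group at this position, with the higher number going to the ring of carbon only and the lower number to the ring that holds a nitrogen and a methoxy group. The data available offer no explanation for this step.

Within the data shown here, the single step does not separate the ring nitrogen from the methoxy group, so it remains open whether a plain pyridin-2-yl or a methoxyphenyl at this position would stand nearer to compound 1 or to compound 3 in this assay. Going by these compounds, it also remains open how this position responds to groups of a different kind, such as an amine or a carboxylic acid carried on the phenyl ring, and whether the step holds on any other core.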